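This account rests on a few compounds, and the source may have more. Where it says the series, first, only, none or still open, it means among the compounds named here.

This account follows a single change made to compound 2, whose structure is `CC1(C)C[C@@H](C(N)=O)N(Cc2ccc(OCc3cccc(F)c3)cc2)C1`. Among the measured compounds shown here, in an assay on Sf9 cells for inhibition of Amine oxidase [flavin-containing] B (Homo sapiens), with stated times of 15 min and 60 min (on this read-out lower numbers stand for stronger inhibition and higher numbers for weaker inhibition), compound 2 gives 1420 nM, the higher of the two numbers measured so far and therefore the weaker of the two inhibitors. For the measured compounds named here, the only other measured compound, compound 1 with structure `C#CCN(Cc1ccc(OCc2cccc(F)c2)cc1Cl)[C@@H](C)C(N)=O`, gives 68 nM in this assay, a gap from compound 2 that lies beyond the usual scatter; the two compounds differ in several places at once, so no single step between them is counted.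

Compound 3, with structure `CC1(C)C[C@@H](C(N)=O)N(Cc2ccc(OCc3cccc(F)c3)cc2F)C1`, has not yet been measured in this assay. It differs from compound 2 in one place: fluoro in place of hydrogen on an aromatic carbon. Going by the values given here, no measured pair in this set isolates that change, so the expectation rests on the two values shown and on the change itself. Compound 3 is expected to give a somewhat lower number than compound 2, a step of a 2.4-fold lower number from compound 2 to compound 3 (0.37 log units; beyond the scatter), though a step within the scatter would not be surprising. The estimate for compound 3 in this assay is 600 nM, with a range from 200 nM to 2000 nM.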

Compound 3, half-maximal inhibitory concentration: 6350 nM
Beside the measured number, compound 3's estimate is 11-fold (1.02 log units) below it, outside the stated range (above it).
By their numbers in this assay, from the lowest: compound 1; then compound 2; then compound 3.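

In this assay, fluoro in place of hydrogen on an aromatic carbon, ortho to a large group and meta to a (3-fluorobenzyl)oxy group, gives a 4.5-fold higher number from compound 2 to compound 3 (0.65 log units; beyond the scatter). Among the compounds shown here, this is the first change in the set that can be read on its own, and it shows that this ring position is not indifferent: a single added fluorine atom, with no ring, no net charge and only one heavy atom, moves the series toward weaker inhibition by a modest step that still lies beyond the usual scatter. Nothing available bears on why the number rises with this change.

The compounds shown leave open whether the step belongs to fluoro in particular or to any group placed on this carbon, a question that a methyl, a methoxy or a nitrile group at the same place would help to answer. They also leave open whether the same change would have a step of similar direction and size on the core of compound 1, since that compound differs from compound 2 in several places.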